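A few compounds are considered here, and "the series" means these few. Any claim that something is new, unique, unknown or untested is made for them only; others in the source may bear on it.

Measured so far:
- compound 1 `Cc1cc(OC2CCCCC2)c(S(C)(=O)=O)cc1C(=O)N=C(N)N`: 37 nM
- compound 2 `Cc1cc(-n2ccnc2)c(S(C)(=O)=O)cc1C(=O)N=C(N)N`: 23 nM

Two compounds of the series have been run in a functional assay for inhibition of sodium/hydrogen exchanger (Oryctolagus cuniculus); on this read-out lower numbers stand for stronger inhibition and higher numbers for weaker inhibition. Compound 1 `Cc1cc(OC2CCCCC2)c(S(C)(=O)=O)cc1C(=O)N=C(N)N` gives 37 nM, compound 2 `Cc1cc(-n2ccnc2)c(S(C)(=O)=O)cc1C(=O)N=C(N)N` gives 23 nM. Among the measured compounds shown here, the single step between them, a 1.6-fold lower number from compound 1 to compound 2 (0.21 log units; within the scatter), is within the scatter, so compound 2 cannot be separated from compound 1 on this read-out; the two stand at the same level.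

Compound 3 `Cc1ccc(S(C)(=O)=O)cc1C(=O)N=C(N)N` has not yet been measured in this assay. It differs from compound 2 as follows: hydrogen in place of 1H-imidazol-1-yl on an aromatic carbon. For the measured compounds named here, no measured step bears directly on this change: the only step in hand swaps one group for another at this aromatic carbon, and it shows that the two groups are interchangeable within the scatter. Neither measured compound carries hydrogen at this place, so the effect of removing the group altogether is not covered by the data. The working expectation is a weaker inhibition, that is a higher number, of the size a 4.3-fold higher number from compound 2 to compound 3 (0.64 log units; beyond the scatter), with wide uncertainty. Compound 3 is accordingly estimated at 100 nM, range 30 nM to 400 nM, in this assay.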

Compound 3, half-maximal inhibitory concentration: 150 nM
For compound 3 the middle estimate is 1.5-fold (0.18 log units) below the measured one; the range from low to high includes it.
By their numbers in this assay, from the lowest: compounds 2 and 1 (each within the scatter of the next); then compound 3.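

In this assay, the substituted compounds and the unsubstituted one do not stand at the same level: hydrogen in place of 1H-imidazol-1-yl gives a 6.5-fold higher number from compound 2 to compound 3 (0.81 log units; beyond the scatter) and hydrogen in place of cyclohexyloxy gives a 4.1-fold higher number from compound 1 to compound 3 (0.61 log units; beyond the scatter) on this aromatic carbon ortho to the methylsulfonyl group. The earlier pair showed only that two different groups at this place could not be separated, whereas these steps show that an occupied carbon here gives lower numbers than a bare one, for both groups and with no compound shown going against this. No measurement shown accounts for the gap between hydrogen and these two groups.

Going by these compounds, whether a small group at this carbon, such as a methoxy group, chlorine or an amine, would stand with compound 1 and compound 2 or with compound 3 remains open. On these data alone, with only a five-membered aromatic ring and cyclohexyloxy in hand, the range of groups that hold this level is also open, and a carboxylic acid or a longer alkyl chain at the same place would probe it.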